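This account rests on a few compounds, and the source may have more. Where it says the series, first, only, none or still open, it means among the compounds named here.

Measured compounds and their values:
Compound 1, `COc1ccccc1C(=O)NCc1ccc(CNS(=O)(=O)c2ccc([N+](=O)[O-])cc2)cc1`, gives 100 nM in an assay on MDA-MB-231 cells for displacement of a labelled ligand from C-X-C chemokine receptor type 4 (Homo sapiens), read by fluorescence and microscopy, with stated times of 10 min and 30 min; on this read-out higher numbers stand for an effect only at larger amounts of compound and lower numbers for an effect already at smaller amounts.
Compound 2, `Cc1ccccc1C(=O)NCc1ccc(CNS(=O)(=O)c2ccc([N+](=O)[O-])cc2)cc1`, gives 100 nM.
Compound 3, `COc1ccccc1C(=O)NCc1ccc(CNS(=O)(=O)c2cccc3ccccc23)cc1`, gives only a limit of the assay, > 1000 nM.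

Compound 2 stands level with compound 1 on the numbers shown, since no change at the digits printed from compound 1 to compound 2 (within the scatter). The value of compound 3 is a limit and not a number, as noted in the limit of > 1000 nM in this assay, at which 1 of the 3 values shown sits.

Compound 4, `Cc1ccccc1C(=O)NCc1ccc(CNS(=O)(=O)c2ccccc2C)cc1`, has not been measured. It differs from compound 2 as follows: 2-methylphenyl in place of 4-nitrophenyl on a sulfonyl sulfur. For the measured compounds named here, the one measured step at the same place, the sulfonyl sulfur, is an at least 10-fold higher number from compound 1 to compound 3 (1.00 log units; beyond the scatter), where naphthalen-1-yl replaced 4-nitrophenyl; it shows that this position responds to a change of the aryl group, though with a different group than 2-methylphenyl. The step of no change at the digits printed from compound 1 to compound 2 (within the scatter), methyl for methoxy at another place, gave no change. Going by the values given here, no measured pair shows methyl for nitro on the sulfonyl aryl, so the expectation is tentative: a step toward higher numbers, smaller than the one seen for compound 3, is expected, a 4.0-fold higher number from compound 2 to compound 4 (0.60 log units; beyond the scatter). Compound 4 is therefore estimated at 400 nM, within 100 nM to 2000 nM.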

Compound 4, effective concentration (reported as EC, without a stated level of effect): 10 nM
Compound 4: the middle estimate sits 40-fold (1.60 log units) above what was measured; measured number outside the range, below it.
By their numbers in this assay, from the lowest: compound 4; then compounds 1 and 2 (each within the scatter of the next). At a limit, above all of these: compound 3.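

On a sulfonyl sulfur, the aryl group can move the read-out in either direction: in this assay, the earlier change gave an at least 10-fold higher number from compound 1 to compound 3 (1.00 log units; beyond the scatter) with naphthalen-1-yl, whereas 2-methylphenyl in place of 4-nitrophenyl gives a 10-fold lower number from compound 2 to compound 4 (1.00 log units; beyond the scatter) and so a beyond-scatter move toward lower numbers. The 4-nitrophenyl group is therefore not required for activity at this position, and a carbon-only aryl group can replace it with a gain. No measurement shown gives a reason for this gain.

From the compounds shown here alone, whether 2-methylphenyl gives a similar step on the methoxy-bearing core of compound 1 remains open. Also open, going by these compounds, is how the position responds to an aryl group bearing an amine or a carboxylic acid, or to a saturated cyclohexyl group on the sulfonyl sulfur.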